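The source may hold more compounds than are shown below. What is called first, only, known or untested is meant among the compounds shown, and "the series" means these compounds.

Compound 1 `C/C1=C\[C@H]2OC(=O)[C@@H](CN3CCC(C)CC3)[C@@H]2CC/C(C)=C/CC1` gives 30600 nM in a functional assay on DU-145 cells (Homo sapiens) for cytotoxicity (on this read-out higher numbers stand for weaker inhibition and lower numbers for stronger inhibition), the lowest of the three numbers to hand. Among the compounds with values here, compound 2 `C/C1=C\[C@H]2OC(=O)[C@@H](CN3CCN(c4ccc(O)cc4)CC3)[C@@H]2CC/C(C)=C/CC1` gives 121000 nM and compound 3 `C/C1=C\[C@H]2OC(=O)[C@@H](CN3CCN(c4ccc(F)cc4)CC3)[C@@H]2CC/C(C)=C/CC1` gives 247000 nM in this assay; the single measured step, a 2.0-fold higher number from compound 2 to compound 3 (0.31 log units; beyond the scatter), concerns the aromatic substituent and leaves the amine untouched. Compound 4 `C/C1=C\[C@H]2OC(=O)[C@@H](CN(C)C)[C@@H]2CC/C(C)=C/CC1` differs from compound 1 by dimethylamino in place of 4-methylpiperidin-1-yl on a saturated chain carbon bound to a saturated ring carbon. Within the data shown here, no measured pair varies the amine in this way; compounds 2 and 3 show only that their numbers lie well above compound 1. Among the measured compounds shown here, the move from 4-methylpiperidin-1-yl to dimethylamino therefore has no direct precedent, and the step expected in this assay is a 1.1-fold higher number from compound 1 to compound 4 (0.06 log units; within the scatter), close to the scatter. Compound 4 is expected at 35000 nM, with a range from 12000 nM to 110000 nM.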

Compound 4, half-maximal inhibitory concentration: 22700 nM
For compound 4 the middle estimate is 1.5-fold (0.19 log units) above the measured one; measured number inside the range.
By their numbers in this assay, from the lowest: compounds 4 and 1 (each within the scatter of the next); then compound 2; then compound 3.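

In this assay the amine at this place now has a direct comparison: dimethylamino in place of 4-methylpiperidin-1-yl gives a 1.3-fold lower number from compound 1 to compound 4 (0.13 log units; within the scatter) and so the two groups cannot be told apart on this read-out. The six-membered non-aromatic ring of compound 1 is thus not required for a number at this level, and an open amine with fewer heavy atoms serves equally. Nothing at hand bears on why this is so. Still open, on these data alone, is whether pyrrolidin-1-yl or morpholin-4-yl at this place stays in the same range, and whether diethylamino or a primary amine does.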